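The source may hold more compounds than are shown below. What is called first, only, known or untested is meant among the compounds shown, and "the series" means these compounds.

Measured compounds:
- compound 1 `O=C(O)c1cn(Cc2ccc(-c3ccccc3)cc2)c2cc(NC[C@@H]3CCNC3)c(F)cc2c1=O`: 104000 nM
- compound 2 `O=C(O)c1cn(Cc2ccc(-n3cccn3)cc2)c2cc(NC[C@@H]3CCNC3)c(F)cc2c1=O`: 200000 nM
- compound 3 `NC[C@@H]1CCN(c2cc3c(cc2F)c(=O)c(C(=O)O)cn3Cc2cc(-c3ccccc3)no2)C1`: 58300 nM

The read-out throughout is an assay on isolated protein for inhibition of DNA topoisomerase 1 (Homo sapiens), with a stated time of 15 min; a higher number here means a weaker inhibitor, a lower number a stronger inhibitor. Among the three measured compounds, compound 1 has the second highest number; its nearest neighbour is compound 3, whose value differs from it only within the scatter, and the furthest is compound 2, whose value again differs only within the scatter. Among the compounds with values here, the only one-place step measured, a 1.9-fold higher number from compound 1 to compound 2 (0.28 log units; within the scatter), swaps a group on the benzyl arm, not the amine side chain, so nothing here measures the change that leads to compound 4 `O=C(O)c1cn(Cc2ccc(-c3ccccc3)cc2)c2cc(N3C[C@H]4CCNC[C@H]4C3)c(F)cc2c1=O`. That change is a group of 9 heavy atoms (7 carbon, 2 nitrogen; one five-membered non-aromatic ring with 1 hetero atom, one six-membered non-aromatic ring with 1 hetero atom) in place of a group of 7 heavy atoms (5 carbon, 2 nitrogen; one five-membered non-aromatic ring with 1 hetero atom), on an aromatic carbon, replacing the open-chain amine with a fused bicyclic amine on the shared core. Compound 3 carries its amine through a ring nitrogen too, but also a different benzyl arm, so it gives no clean comparison. Within the data shown here, with no step bearing on it, the expectation for compound 4 is a number close to compound 1, the estimated step of a 1.5-fold lower number from compound 1 to compound 4 (0.17 log units; within the scatter) lying within the scatter. Compound 4 is therefore estimated at 70000 nM, with a range from 25000 nM to 250000 nM.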

Compound 4, half-maximal inhibitory concentration: 61000 nM
For compound 4 the middle estimate is 1.1-fold (0.06 log units) above the measured one; low and high end bracket the measured number.
By their numbers in this assay, from the lowest: compounds 3, 4, 1 and 2 (each within the scatter of the next, the first and the last beyond it).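

In this assay, putting the fused bicyclic amine in place of the ((pyrrolidin-3-yl)methyl)amino group gives a 1.7-fold lower number from compound 1 to compound 4 (0.23 log units; within the scatter). This is the first one-place change shown at this aromatic carbon, ortho to the fluoro group, as the earlier step altered only the benzyl arm; it shows that a group with two non-aromatic rings can stand here without moving the number beyond the scatter. No measured information is available to explain this result.

The compounds shown leave open whether a piperazine, or an open-chain amine longer than the one in compound 1, would move the number beyond the scatter on the shared core. They also leave open whether the two defined stereocentres of the fused amine matter, and whether this swap would give a similar result with the benzyl arm of compound 2.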